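This account rests on a few compounds, and the source may have more. Where it says the series, first, only, none or still open, it means among the compounds named here.

Measured compounds:
- compound 1, `CCc1ccccc1N(CC(=O)NCc1cccc(OC)c1)S(=O)(=O)c1ccc(C)cc1`: 138 nM
- compound 2, `CCc1ccccc1N(CC(=O)NCc1ccc(Cl)cc1)S(=O)(=O)c1ccc(C)cc1`: 11.5 nM
- compound 3, `Cc1ccc(S(=O)(=O)N(CC(=O)NCc2ccc(Cl)cc2)c2ccccn2)cc1`: < 1450 nM

In a functional assay on CHO-K1 cells for antagonist activity at prostaglandin E2 receptor EP1 subtype (Homo sapiens), read by FLIPR and calcium flux (on this read-out higher numbers stand for weaker inhibition and lower numbers for stronger inhibition), compound 1 gives 138 nM. Compound 2 gives 11.5 nM, a step of a 12-fold lower number from compound 1 to compound 2 (1.08 log units; beyond the scatter). For compound 3 only a limit is known, < 1450 nM, which is one of the values that sit at the limit of < 1450 nM in this assay, at which 1 of the 3 values shown sits. The step that the limit leaves unreadable from compound 2 to compound 3 therefore cannot be read in size.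

Compound 4, `Cc1ccc(S(=O)(=O)N(CC(=O)NCc2ccc(Cl)cc2)c2ncccc2C)cc1`, differs from compound 3 by methyl in place of hydrogen on an aromatic carbon. Going by the values given here, no measured step shows the effect of this change directly, and the only step touching the sulfonamide-nitrogen ring ends at a limit. A modest step is expected, a step that the limit leaves unreadable from compound 3 to compound 4, with compound 4 estimated at 200 nM, between 20 nM and 1450 nM.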

Compound 4, inhibition constant: < 1450 nM
Compound 4: a limit, no number; the forecaster's own chance of this, stated with the estimate: 30%; the middle value lies beyond the limit too.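

In this assay compound 4 gives < 1450 nM, a limit and not a number. Its steps from compound 2 and compound 3 therefore cannot be read: the limit of < 1450 nM in this assay, at which 2 of the 4 values shown sit.

The compounds shown leave open whether methyl in place of hydrogen on an aromatic carbon changes inhibition at all.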